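The source may report more compounds than this note shows. Statements on the series, on what has been measured and on what is new or still open speak of the compounds shown alone.

Measured compounds in a functional assay on SGC-7901 cells (Homo sapiens) for antiproliferative activity, read by sulforhodamine B assay, with a stated time of 72 h; a higher number here means a weaker inhibitor, a lower number a stronger inhibitor:
- compound 1 `NC(=S)N/N=C/c1ccc2ccccc2n1`: 32700 nM
- compound 2 `COc1ccc(C)cc1NC(=S)N/N=C/c1ccc2ccccc2n1`: > 100000 nM, a limit of the assay rather than a number
- compound 3 `S=C(N/N=C/c1ccc2ccccc2n1)Nc1ccc(Br)cc1`: 69400 nM

Compound 3 gives the highest of the two numbers shown; its nearest neighbour is compound 1, with a 2.1-fold higher number from compound 1 to compound 3 (0.33 log units; beyond the scatter). Within the data shown here, the only other aryl-bearing member, compound 2, sits at the limit of > 100000 nM in this assay, at which 1 of the 3 values shown sits.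

Compound 4 `Fc1cccc(NC(=S)N/N=C/c2ccc3ccccc3n2)c1` differs from compound 3 by 3-fluorophenyl in place of 4-bromophenyl on an amide-type nitrogen. Among the measured compounds shown here, the one measured step that bears on the change is a 2.1-fold higher number from compound 1 to compound 3 (0.33 log units; beyond the scatter), which shows that putting an aryl group on that nitrogen costs a modest amount; the move from one aryl to another within the same class of substituent has no measured precedent here. The two aryl members known, compound 3 and compound 2, lie in the weak range, the latter at a limit. For compound 4 the expected number is therefore close to that of compound 3, with a 1.1-fold higher number from compound 3 to compound 4 (0.03 log units; within the scatter), a step within the scatter and leaning, if anything, towards a weaker inhibitor. Compound 4 is estimated at 75000 nM, with a range from 30000 nM to 160000 nM.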

Compound 4, half-maximal inhibitory concentration: 79900 nM
Beside the measured number, compound 4's estimate is 1.1-fold (0.03 log units) below it; measured number inside the range.
By their numbers in this assay, from the lowest: compound 1; then compounds 3 and 4 (each within the scatter of the next). At a limit, above all of these: compound 2.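

In this assay, 3-fluorophenyl in place of 4-bromophenyl on the amide-type nitrogen leaves the two compounds within the scatter of each other, with a 1.2-fold higher number from compound 3 to compound 4 (0.06 log units; within the scatter). The cost of an aryl group in place of hydrogen at this nitrogen now appears with a second aryl group, at a 2.4-fold higher number from compound 1 to compound 4 (0.39 log units; beyond the scatter), so it is not confined to 4-bromophenyl. Compound 2, the remaining aryl member, gives a limit of the assay and not a number: the limit of > 100000 nM in this assay, at which 1 of the 4 values shown sits.

The step changes both the halogen and its place on the phenyl ring, so the two effects cannot be told apart from compound 3 and compound 4 alone. On these data alone, whether an ethyl chain, a morpholine or a phenyl ring bearing a carboxylic acid on that nitrogen would give a lower number than compound 1 stays open.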